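The source may hold more compounds than are shown below. What is called first, only, known or untested is meant among the compounds shown, and "the series" means these compounds.

In a functional assay on DU-145 cells (Homo sapiens) for inhibition, read by trypan blue exclusion, with a stated time of 96 h (a higher number here means a weaker inhibitor of growth, a lower number a stronger inhibitor of growth), compound 1 (`O=C(/C(=C\c1ccc(O)cc1O)Sc1ccc(Br)cc1)c1ccc(Cl)cc1`) gives 50000 nM, while compound 2 (`O=C(/C(=C\c1ccccc1OCc1ccccc1)Sc1ccc(Br)cc1)c1ccc(Cl)cc1`) gives 10000 nM. Compound 2 therefore holds the lower of the two numbers, and the gap between them lies beyond the usual scatter of repeated measurements. Even so, compound 2 needs a fairly high concentration to inhibit cell growth.

Compound 3 (`COc1ccccc1/C=C(/Sc1ccc(Br)cc1)C(=O)c1ccc(Cl)cc1`) differs from compound 2 in one place, with hydrogen in place of phenyl on a saturated chain carbon bound to an oxygen on an aromatic ring, which turns benzyloxy into methoxy: hydrogen in place of phenyl on a saturated chain carbon bound to an oxygen on an aromatic ring.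

Going by the values given here, no measured pair of compounds shows the effect of this change, so any forecast is uncertain. Among the compounds with values here, the only other measured number is that of compound 1 at 50000 nM, which suggests a modest drift upward in this assay rather than a gain. The estimated step of a 2.0-fold higher number from compound 2 to compound 3 (0.30 log units; within the scatter) is small, toward weaker growth inhibition and near the edge of the scatter. For compound 3 the expected value is 20000 nM, with an estimated range of 6000 nM to 60000 nM.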

Compound 3, concentration for 50% growth inhibition: 10000 nM
Compound 3: the middle estimate sits 2.0-fold (0.30 log units) above what was measured; low and high end bracket the measured number.
By their numbers in this assay, from the lowest: compounds 2 and 3 (each within the scatter of the next); then compound 1.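

In this assay, hydrogen in place of phenyl on a saturated chain carbon bound to an oxygen on an aromatic ring gives no change at the digits printed from compound 2 to compound 3 (within the scatter), so the phenyl of the benzyloxy group is not required to keep the number at this level. Going by these compounds, with 2-methoxyphenyl in place of 2,4-dihydroxyphenyl, the result is a 5.0-fold lower number from compound 1 to compound 3 (0.70 log units; beyond the scatter), so the gap from compound 1 stays open with methoxy as it does with benzyloxy, and it does not depend on the phenyl. No supporting measurement explains either result.

The step between compound 1 and compound 3 replaces the whole substituted ring group at once, so it cannot show how much each hydroxy or the methoxy contributes on its own. On these data alone, it also remains open whether a longer chain such as ethoxy, or an amine in place of the ether oxygen, would keep this number or move it, and compound 3 at 10000 nM still needs a fairly high concentration to inhibit growth.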